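This account rests on a few compounds, and the source may have more. Where it says the series, first, only, none or still open, it means among the compounds named here.

Compound 1 `Cc1c(C(=O)N/N=C\c2c(O)cccc2F)oc2cccc(O)c12`: 1750 nM
Compound 2 `Cc1c(C(=O)N/N=C\c2ccc(O)cc2O)oc2cccc(O)c12`: 2080 nM

In a functional assay on MCF7 cells (Homo sapiens) for inhibition (a higher number here means a weaker inhibitor, a lower number a stronger inhibitor), compound 2 stands alongside compound 1, as the step of a 1.2-fold higher number from compound 1 to compound 2 (0.08 log units; within the scatter) is within the scatter. Compound 3 `Cc1c(C(=O)N/N=C\c2ccc(O)c(O)c2O)oc2cccc(O)c12` differs from compound 2 by hydroxy in place of hydrogen on an aromatic carbon. Among the compounds with values here, the only measured step, a 1.2-fold higher number from compound 1 to compound 2 (0.08 log units; within the scatter), exchanged one hydroxy-bearing ring for another and moved little; no measured step adds a hydroxy to an aromatic carbon, so it gives only indirect guidance. The expected step of a 1.0-fold lower number from compound 2 to compound 3 (0.02 log units; within the scatter) is therefore small, with no direction beyond the scatter. For compound 3 the estimate in this assay is 2000 nM, with a range from 900 nM to 4500 nM.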

Compound 3, half-maximal inhibitory concentration: 17100 nM
Compound 3: the middle estimate sits 8.6-fold (0.93 log units) below what was measured, and the stated range ends below it.
By their numbers in this assay, from the lowest: compounds 1 and 2 (each within the scatter of the next); then compound 3.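

In this assay, placing one more hydroxy on the aromatic carbon ortho to two hydroxy groups gives an 8.2-fold higher number from compound 2 to compound 3 (0.91 log units; beyond the scatter) and so clearly weakens inhibition. The earlier change of ring pattern, a 1.2-fold higher number from compound 1 to compound 2 (0.08 log units; within the scatter), had not shown that a single added hydroxy on this ring could matter this much. Nothing at hand explains the loss.

Still open, from the compounds shown here alone, is whether the loss is specific to hydroxy or would follow any group on this carbon. A methoxy or an amine at the same place would help to tell these apart.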